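The source may report more compounds than this note shows. Statements on the series, on what has been measured and on what is new or still open speak of the compounds shown alone.

Measured so far in an ADME assay on J774 cells (Mus musculus) for cytotoxicity; on this read-out higher numbers stand for an effect only at larger amounts of compound and lower numbers for an effect already at smaller amounts:
Compound 1 `CCCCc1cc2c(=O)c(C(=O)O)c[nH]c2cc1OCCOc1ccccc1`: > 20000 nM, which is a limit of the assay and not a number.
Compound 2 `CCCCc1cc2c(=O)cc[nH]c2cc1OCCOc1ccccc1`: > 20000 nM, again only a limit.

Compound 2 thus stands at the limit of > 20000 nM in this assay, at which 2 of the 2 values shown sit. Going by the values given here, the one measured change, a step that the two limits leave unreadable from compound 1 to compound 2, is unreadable, since both ends are limits. Compound 3 `CCCCc1cc2c(=O)c(C(=O)NCC)c[nH]c2cc1OCCOc1ccccc1` differs from compound 2 by ethylcarbamoyl in place of hydrogen on an aromatic carbon. Among the compounds with values here, no measured step gives a readable size for this kind of change, so no effect beyond the scatter is expected in this assay. Compound 3 is therefore estimated at 30000 nM, with a range of 12000 nM to 100000 nM. The step that the limit leaves unreadable from compound 2 to compound 3 that this estimate implies is expected to stay within the scatter.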

Compound 3, half-maximal effective concentration: > 20000 nM
Compound 3 ended at the assay's limit (the forecaster's own chance of this, stated with the estimate: 80%); the middle value lies beyond the limit too.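

No new step can be read for compound 3 against compound 1 or compound 2, since each value is a limit and not a number: the limit of > 20000 nM in this assay, at which 3 of the 3 values shown sit. The compounds shown leave open whether carboxy, hydrogen or ethylcarbamoyl at this place makes any difference in this assay.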